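Boronic acid series: plasma distribution across sulfonamide nitrogen substituents

The compounds below may be only part of what the source reports. "The series", "measured", "known", "first", "only" and "open" are said of these compounds alone.

Measured compounds in an ADME assay on the whole organism (Rattus norvegicus) for pharmacokinetics, read by LC-MS, at a dose of 1 mg/kg by the intravenous route; a lower number here means that more of the compound stays in the plasma, a higher number that more of the compound sits outside the plasma:
compound 1 `CNC(=O)c1c(-c2ccc(F)cc2)oc2cc(N(Cc3ccc(B(O)O)c(F)c3)S(C)(=O)=O)c(C3CC3)cc12` gives 1.4 L/kg
compound 2 `CNC(=O)c1c(-c2ccc(F)cc2)oc2cc(N(c3ccc(B(O)O)c(Cl)c3)S(C)(=O)=O)c(C3CC3)cc12` gives 1.1 L/kg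
compound 3 `CNC(=O)c1c(-c2ccc(F)cc2)oc2cc(-n3ncnc3-c3ccc(B(O)O)c(F)c3)c(C3CC3)cc12` gives 0.9 L/kg

All three measured compounds share one core and differ only in the boronic-acid-bearing group on the sulfonamide nitrogen or its replacement by a triazole linker. Their numbers in this assay sit close together: compound 2 lies between compound 1 and compound 3, and both gaps are within the scatter of repeated measurements, so no ordering among them can be read.

Among the compounds with values here, the one measured step that bears directly on the sulfonamide nitrogen is a 1.3-fold lower number from compound 1 to compound 2 (0.10 log units; within the scatter). Exchanging one boronic-acid-bearing aryl group for another therefore moved the number by less than the scatter.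

Compound 4 `CNC(=O)c1c(-c2ccc(F)cc2)oc2cc(N(C3CCc4c(B(O)O)cccc43)S(C)(=O)=O)c(C3CC3)cc12` carries, relative to compound 2, (a group of 12 heavy atoms (9 carbon, 1 boron, 2 oxygen; one five-membered non-aromatic ring of carbon only, one six-membered aromatic ring of carbon only) in place of a group of 10 heavy atoms (6 carbon, 1 boron, 2 oxygen, 1 chlorine; one six-membered aromatic ring of carbon only), on a sulfonamide nitrogen). The change is again a swap of the boronic-acid-bearing group on the same nitrogen, and the measured comparison between compound 1 and compound 2 gives no sign that such swaps shift the number beyond the scatter. The step from compound 2 to compound 4 is therefore expected to be small, a 1.1-fold higher number from compound 2 to compound 4 (0.04 log units; within the scatter), with no direction claimed beyond the scatter. For compound 4 the estimate in this assay is 1.2 L/kg, with a range of 0.7 L/kg to 2.2 L/kg.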

Compound 4, volume of distribution at steady state: 3.5 L/kg
Compound 4: middle estimate off by 2.9-fold (0.46 log units), on the low side; measured number above the stated range.
By their numbers in this assay, from the lowest: compounds 3, 2 and 1 (each within the scatter of the next); then compound 4.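

The sulfonamide nitrogen can carry a change that moves the number in this assay beyond the scatter, with a 3.2-fold higher number from compound 2 to compound 4 (0.50 log units; beyond the scatter) and a 2.5-fold higher number from compound 1 to compound 4 (0.40 log units; beyond the scatter) as the two steps that show it. Swaps of the boronic-acid-bearing group at this nitrogen are therefore not uniformly silent: the step between compound 1 and compound 2 stays within the scatter, while both steps to compound 4, whose entering group holds one five-membered non-aromatic ring of carbon only, lie beyond it. No measurement shown here accounts for this shift.

As far as these compounds go, whether the higher number follows the five-membered ring or another feature of the entering group stays open. A carboxylic acid in place of the boronic acid, or an amine on the five-membered ring, would show how far this change extends.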